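Chloro for fluoro, carried onto a second core

The source may hold more compounds than are shown below. What is called first, only, known or untested is meant among the compounds shown, and "the series" means these compounds.

Two measured analogues share one core: compound 1 `O=S(=O)(/C=C/c1ncccc1F)c1ccccc1F` and compound 2 `O=S(=O)(/C=C/c1ncccc1Cl)c1ccccc1F`. In an assay on U2OS cells for activation of nuclear factor erythroid 2-related factor 2 (Homo sapiens), read by beta-arrestin recruitment, with a stated time of 6 h (a lower number here means that less compound is needed, a higher number that more compound is needed for the effect), compound 1 gives 176 nM, and compound 2 gives 30 nM. The change between them is chloro in place of fluoro on an aromatic carbon, and it brought a 5.9-fold lower number from compound 1 to compound 2 (0.77 log units; beyond the scatter).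

Compound 3 `O=S(=O)(/C=C/c1ncccc1F)c1cccc(F)c1` has the same atoms as compound 1, joined differently; the difference between the two cores is not broken down here. In this assay, within the data shown here, compound 3 gives 474 nM, the highest of the three numbers so far and beyond the scatter from each of the other two.

Compound 4 `O=S(=O)(/C=C/c1ncccc1Cl)c1cccc(F)c1` is not yet measured. It differs from compound 3 by chloro in place of fluoro on an aromatic carbon. The place of this change is the same, word for word, as the place of the change from compound 1 to compound 2, so it is the same kind of change made on a different core, and it occurs twice among the compounds shown. Among the measured compounds shown here, the only guide to its size is the single earlier step, so the expectation rests on one pair.

For compound 4 in this assay the expected step is a 5.6-fold lower number from compound 3 to compound 4 (0.75 log units; beyond the scatter), close to the earlier step because of a 5.9-fold lower number from compound 1 to compound 2 (0.77 log units; beyond the scatter), with a wide range since one pair on one core gives no measure of how far the step carries. Compound 4 is estimated at 85 nM, between 35 nM and 220 nM.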

Compound 4, half-maximal effective concentration: 84 nM
Compound 4: middle estimate off by 1.0-fold (0.01 log units), on the high side; the measured number falls inside the stated range.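

In this assay, chloro in place of fluoro on an aromatic carbon again brought a clear gain on the second core, with a 5.6-fold lower number from compound 3 to compound 4 (0.75 log units; beyond the scatter). The size of the step carried over between the two cores, which hold the same atoms joined differently: the same change on two cores in this assay, a 5.9-fold lower number (0.77 log units; beyond the scatter) from compound 1 to compound 2 and a 5.6-fold lower number (0.75 log units; beyond the scatter) from compound 3 to compound 4, 1.0-fold (0.02 log units) apart, within the scatter of two such steps. This is agreement between two pairs in one assay and shows only that, on these two cores, the step did not depend on how the atoms differ between them; it does not show that the step would hold on a core changed in any other way, and it gives no reason for the gain.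

The compounds shown leave open whether chloro is the best group at this place, since bromo, methyl, methoxy and nitrile do not appear there, so the trend rests on a single exchange of one halogen for another. Also open, going by these compounds, is whether the step survives when the fluoro on the other side of the sulfonyl group gives way to an amine, a carboxylic acid or a longer chain.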